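Para substituent changes on the shared core

The source may report more compounds than this note shows. Statements on the series, on what has been measured and on what is new or still open speak of the compounds shown alone.

Measured so far:
Compound 1 `COc1ccc(-c2coc3c(=O)n(O)c(=O)[nH]c23)cc1`: 0.034 nM in an assay on isolated protein for inhibition of Flap endonuclease 1 (Homo sapiens); a lower number here means a stronger inhibitor, a higher number a weaker inhibitor
Compound 2 `O=c1[nH]c2c(-c3ccc(Br)cc3)coc2c(=O)n1O`: 0.076 nM in this assay

Compound 2 holds the highest of the two numbers in this assay; its nearest neighbour is compound 1, and the step of a 2.2-fold higher number from compound 1 to compound 2 (0.35 log units; beyond the scatter) lies beyond the scatter.

Compound 3 `O=c1[nH]c2c(-c3ccc(-c4ccccc4)cc3)coc2c(=O)n1O` differs from compound 2 by phenyl in place of bromo on an aromatic carbon. Going by the values given here, no measured step involves a phenyl at that carbon; the only step so far, a 2.2-fold higher number from compound 1 to compound 2 (0.35 log units; beyond the scatter), concerns methoxy against bromo and bears on this change only by showing that a swap at the same carbon moved the number modestly. On that basis a step of similar or smaller size is expected for a 1.3-fold higher number from compound 2 to compound 3 (0.12 log units; within the scatter), direction uncertain, possibly within the scatter.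

Compound 3 is therefore estimated at 0.1 nM in this assay, with a range from 0.03 nM to 0.3 nM.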

Compound 3, half-maximal inhibitory concentration: 0.023 nM
Beside the measured number, compound 3's estimate is 4.3-fold (0.64 log units) above it; measured number outside the range, below it.
By their numbers in this assay, from the lowest: compounds 3 and 1 (each within the scatter of the next); then compound 2.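

In this assay this carbon takes a whole added six-membered aromatic ring of carbon only without any loss: phenyl in place of bromo gives a 3.3-fold lower number from compound 2 to compound 3 (0.52 log units; beyond the scatter) and so moves the number toward the stronger end. Phenyl in place of methoxy gives a 1.5-fold lower number from compound 1 to compound 3 (0.17 log units; within the scatter) and so does not separate compound 1 from compound 3, which leaves compound 2 as the only one of the three set apart from both others by steps beyond the scatter. No measurement at hand accounts for these differences.

Open, from the compounds shown here alone, is whether the number holds with groups of another kind at this carbon, such as an amine, a carboxylic acid or a longer chain. Also open, going by these compounds, is whether a substituent on the added phenyl itself would move the number.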